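A few compounds are considered here, and "the series" means these few. Any claim that something is new, unique, unknown or untested is made for them only; others in the source may bear on it.

Measured so far in a functional assay on MCF7 cells (Homo sapiens) for antiproliferative activity, read by MTT assay, with a stated time of 72 h; a lower number here means a stronger inhibitor, a higher number a weaker inhibitor:
- compound 1 `C/C=C/C(=O)Nc1cccc(Oc2nc(Nc3ccn(C)n3)nc3c2CSCC3)c1`: 40000 nM
- compound 2 `C/C=C/C(=O)Nc1cccc(Oc2nc(Nc3cccc(C#N)c3)nc3c2CSCC3)c1`: 21400 nM

Among the compounds with values here, compound 2 lies within the scatter of compound 1, the only other compound measured. Compound 3 `C/C=C/C(=O)Nc1cccc(Oc2nc(Nc3ccc(OC)cc3)nc3c2CSCC3)c1` differs from compound 2 in one place: 4-methoxyphenyl in place of 3-cyanophenyl on a nitrogen on an aromatic ring. Within the data shown here, one measured step bears on this, as it also swaps the group on such a nitrogen: a 1.9-fold lower number from compound 1 to compound 2 (0.27 log units; within the scatter). Among the measured compounds shown here, no measured compound carries 4-methoxyphenyl, so the evidence is thin, but no step beyond the scatter is expected. The expected change is a 1.1-fold lower number from compound 2 to compound 3 (0.03 log units; within the scatter). The estimate for compound 3 is 20000 nM, with a range of 8000 nM to 50000 nM.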

Compound 3, half-maximal inhibitory concentration: 24300 nM
The estimate for compound 3 lay 1.2-fold (0.08 log units) below the measured number, and the stated range covers the measured number.
By their numbers in this assay, from the lowest: compounds 2, 3 and 1 (each within the scatter of the next).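

In this assay, replacing 3-cyanophenyl with 4-methoxyphenyl stays within the scatter (a 1.1-fold higher number from compound 2 to compound 3 (0.06 log units; within the scatter)), and so does replacing 1-methyl-1H-pyrazol-3-yl with 4-methoxyphenyl (a 1.6-fold lower number from compound 1 to compound 3 (0.22 log units; within the scatter)). Across compound 1, compound 2 and compound 3, these three groups on a nitrogen on an aromatic ring cannot be told apart by this measurement. Nothing available offers an explanation for this result. Still open, on these data alone, is whether a carboxylic acid or an amine on the phenyl ring, or a longer chain in its place, would give a number beyond the scatter.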